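This account rests on a few compounds, and the source may have more. Where it says the series, first, only, none or still open, it means among the compounds named here.

Measured compounds in a functional assay on A549 cells (Homo sapiens) for antiproliferative activity, read by MTT assay, with a stated time of 48 h; a lower number here means a stronger inhibitor of growth, a higher number a weaker inhibitor of growth:
compound 1 `CCCOC(=O)N1N=C(c2ccccc2)CC1c1cc(OC)c(OC)c(OC)c1` gives > 10000 nM, which is a limit of this assay and not a number.
compound 2 `CCCOC(=O)N1N=C(c2cccc(OC)c2)CC1c1cc(OC)c(OC)c(OC)c1` gives > 10000 nM, again a limit of this assay.
compound 3 `COC(=O)N1N=C(c2ccccc2)CC1c1ccc(OC)cc1` gives 15300 nM, the only number so far.

From compound 1 to compound 2 the change is methoxy in place of hydrogen on an aromatic carbon. The step it made, a step that the two limits leave unreadable from compound 1 to compound 2, cannot be sized because of the limit of > 10000 nM in this assay, at which 2 of the 3 values shown sit. Compound 3 stands on a different core; the difference between the core of compound 3 and the core of compound 1 is not broken down here.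

Compound 4 `COC(=O)N1N=C(c2ccccc2)CC1c1ccc(OC)c(OC)c1` is not yet measured in this assay. From compound 3 to compound 4 the change is methoxy in place of hydrogen on an aromatic carbon. This is the same kind of change as that from compound 1 to compound 2, but the surroundings differ: in compound 4 the entering methoxy sits ortho to a methoxy group (2 heavy atoms) and meta to a large group, whereas in compound 2 it sits only meta to a large group, reading, one bond further out, as phenyl to 3-methoxyphenyl.

Since the earlier step is unreadable, the expectation for compound 4 rests on compound 3 alone, at 15300 nM, which is already weak in this assay. The step from compound 3 to compound 4 is expected to be small, a 1.3-fold lower number from compound 3 to compound 4 (0.11 log units; within the scatter). Compound 4 is therefore estimated at 12000 nM, with a range from 4000 nM to 40000 nM, and a real chance that only a limit is reported.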

Compound 4, concentration for 50% growth inhibition: 7320 nM
For compound 4 the middle estimate is 1.6-fold (0.21 log units) above the measured one; the range from low to high includes it.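

In this assay, methoxy in place of hydrogen on an aromatic carbon gives a 2.1-fold lower number from compound 3 to compound 4 (0.32 log units; beyond the scatter), a modest step, with the entering methoxy ortho to a methoxy group and meta to a large group. The same kind of change on the core of compound 1, leading to compound 2, cannot be read, so the two steps cannot be set against each other and nothing shows that the change carries from one core to the other: the limit of > 10000 nM in this assay, at which 2 of the 4 values shown sit. The result is therefore a single readable step on the core of compound 3, in which compound 4 gives 7320 nM, and since the surroundings of the entering methoxy differ between compound 2 and compound 4, it sets no rule for the series.

The compounds shown leave open whether another group in the same place on the core of compound 3, such as a hydroxy group, an amine or a carboxylic acid, would move the number further than methoxy does. Also open, going by these compounds, is what a longer chain such as a butoxy group would do in that place, and whether any such step would stay readable on the core of compound 1.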